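The compounds below may be only part of what the source reports. "The series", "measured", "known", "first", "only" and "open" are said of these compounds alone.

Measured in a functional assay on A549 cells (Homo sapiens), read by MTT assay, with a stated time of 72 h; a lower number here means a stronger inhibitor, a higher number a weaker inhibitor:
compound 1 `COc1ncnc2c1c(-c1ccoc1)cn2[C@@H]1O[C@H](CO)[C@@H](O)[C@H]1O`: 1160 nM
compound 2 `COc1nc(N)nc2c1c(-c1ccoc1)cn2[C@@H]1O[C@H](CO)[C@@H](O)[C@H]1O`: > 20000 nM

Within the data shown here, compound 1 holds the only number given in this assay. The entry for compound 2 is a limit of the assay, not a number. Among the measured compounds shown here, the one measured step, an at least 17-fold higher number from compound 1 to compound 2 (1.23 log units; beyond the scatter), concerns a different position and so says nothing about the change to compound 3 `C#Cc1cn([C@@H]2O[C@H](CO)[C@@H](O)[C@H]2O)c2ncnc(OC)c12`, which is ethynyl in place of furan-3-yl on an aromatic carbon. For the measured compounds named here, no measured step covers this change, so the expected size and direction rest on the change alone. A loss beyond the scatter is expected for compound 3, estimated at 3500 nM (range 900 nM to 14000 nM). The step expected in this assay is a 3.0-fold higher number from compound 1 to compound 3 (0.48 log units; beyond the scatter).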

Compound 3, half-maximal inhibitory concentration: 8160 nM
For compound 3 the middle estimate is 2.3-fold (0.37 log units) below the measured one, and the stated range covers the measured number.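

The aromatic carbon two ring bonds from the ring nitrogen now has a measured step of its own in this assay: ethynyl in place of furan-3-yl gives a 7.0-fold higher number from compound 1 to compound 3 (0.85 log units; beyond the scatter). At this place, furan-3-yl therefore gives the lower number of the two groups, while compound 3 still reads 8160 nM. Nothing in the data at hand accounts for the size of this step. Open, on these data alone, is whether the ring or the triple bond decides the outcome. A phenyl ring, a thiophene or a longer alkyne chain at this place would bear on that question.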